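Swapping Halogens on a Sulfonamide-Linked Imidazole Series

A few compounds are considered here, and "the series" means these few. Any claim that something is new, unique, unknown or untested is made for them only; others in the source may bear on it.

Compound 1 `O=S(=O)(NCCCNc1nccc(-c2[nH]c(-c3ccccc3)nc2-c2ccc(F)c(O)c2)n1)c1ccc(Br)cc1` gives 5660 nM in a functional assay on LOX IMVI cells (Homo sapiens) for cytotoxicity, read by MTT assay, with a stated time of 24 h; a higher number here means a weaker inhibitor, a lower number a stronger inhibitor.
Compound 2 `O=S(=O)(NCCCNc1nccc(-c2[nH]c(-c3ccccc3)nc2-c2ccc(F)c(O)c2)n1)c1ccc(F)cc1` gives 19200 nM in this assay.
Compound 3 `O=S(=O)(NCCCNc1nccc(-c2[nH]c(-c3ccccc3)nc2-c2ccc(Cl)c(O)c2)n1)c1ccc(Br)cc1` gives 15500 nM in this assay.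

Compound 4 `O=S(=O)(NCCCNc1nccc(-c2[nH]c(-c3ccccc3)nc2-c2ccc(Cl)c(O)c2)n1)c1ccc(F)cc1` has not yet been measured. One change in this set has already been seen once: fluoro in place of bromo on an aromatic carbon, which produced a 3.4-fold higher number from compound 1 to compound 2 (0.53 log units; beyond the scatter). The core of compound 3 differs from that of compound 1 by chloro in place of fluoro on an aromatic carbon, a step of a 2.7-fold higher number from compound 1 to compound 3 (0.44 log units; beyond the scatter). Going from compound 3 to compound 4 the change is fluoro in place of bromo on an aromatic carbon, made at the same place as before, so it is the same change. The step to compound 4 is expected to be a 2.9-fold higher number from compound 3 to compound 4 (0.46 log units; beyond the scatter), an expectation resting on a 3.4-fold higher number from compound 1 to compound 2 (0.53 log units; beyond the scatter) carried over to a second core. Compound 4 is therefore estimated at 45000 nM, most likely between 18000 nM and 110000 nM.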

Compound 4, half-maximal inhibitory concentration: 2300 nM
The estimate for compound 4 lay 20-fold (1.29 log units) above the measured number; measured number outside the range, below it.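

Swapping 4-bromophenyl for 4-fluorophenyl gave a 6.7-fold lower number from compound 3 to compound 4 (0.83 log units; beyond the scatter), the opposite direction to the first time this change was seen: the same change on two cores in this assay, a 3.4-fold higher number (0.53 log units; beyond the scatter) from compound 1 to compound 2 and a 6.7-fold lower number (0.83 log units; beyond the scatter) from compound 3 to compound 4, 23-fold (1.36 log units) apart, beyond the scatter of two such steps. The other change, chloro in place of fluoro on an aromatic carbon, gave an 8.3-fold lower number from compound 2 to compound 4 (0.92 log units; beyond the scatter) and turned round in the same way: the same change on two cores in this assay, a 2.7-fold higher number (0.44 log units; beyond the scatter) from compound 1 to compound 3 and an 8.3-fold lower number (0.92 log units; beyond the scatter) from compound 2 to compound 4, 23-fold (1.36 log units) apart, beyond the scatter of two such steps. Among these four compounds, the effect of each halogen swap depends on the halogen at the other place, so a step seen on one core could not be carried to the other, though these numbers do not show why.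

From the compounds shown here alone, it remains open whether this reversal would also appear with a methyl or methoxy group in place of either halogen. A longer chain between the sulfonamide and the shared core is also untested here.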